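Adding a nitro group where growth inhibition is weak

The compounds below may be only part of what the source reports. "The series", "measured", "known", "first", "only" and "open" are said of these compounds alone.

Compound 1 `CC1=CC[C@H](C(C)(C)NC(=S)N/N=C/c2ccccc2)CC1` carries an unsubstituted aromatic ring at one end of the shared core. In a functional assay on UACC-62 cells (Homo sapiens) for inhibition, read by sulforhodamine B assay, with a stated time of 48 h (a lower number here means a stronger inhibitor of growth, a higher number a weaker inhibitor of growth), compound 1 gives > 100000 nM, which is a limit of the assay rather than a number. Compound 2 `COc1ccc(/C=N/NC(=S)NC(C)(C)[C@H]2CC=C(C)CC2)cc1` bears a methoxy group on that ring, and in this assay compound 2 gives 70400 nM. Compound 3 `CC1=CC[C@H](C(C)(C)NC(=S)N/N=C/c2ccc(F)cc2)CC1` bears a fluoro group on the same ring. In this assay compound 3 gives > 100000 nM, again a limit and not a number. The change from hydrogen to methoxy produced an at least 1.4-fold lower number from compound 1 to compound 2 (0.15 log units; that floor lies within the scatter), while the change to fluoro produced a step that the two limits leave unreadable from compound 1 to compound 3 because the limit of > 100000 nM in this assay, at which 2 of the 3 values shown sit, hides both ends of that step.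

Compound 4 `CC1=CC[C@H](C(C)(C)NC(=S)N/N=C/c2ccccc2[N+](=O)[O-])CC1` introduces (nitro in place of hydrogen on an aromatic carbon). The two measured substitutions on this ring give no sign of a change beyond the scatter, so the step expected is a number no higher from compound 1 to compound 4 (the limit leaves the size open). Compound 4 is therefore estimated at 100000 nM, with a range from 40000 nM to 250000 nM.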

Compound 4, concentration for total growth inhibition: 92200 nM
Compound 4: the middle estimate sits 1.1-fold (0.04 log units) above what was measured; low and high end bracket the measured number.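

With nitro on an aromatic carbon ortho to a large group, compound 4 gives 92200 nM in this assay, a real number rather than a limit, so this change has one end that can be read. The step is an at least 1.0-fold lower number from compound 1 to compound 4 (0.03 log units; that floor lies within the scatter), so nitro at this place, like methoxy on the same ring, shows no gain in growth inhibition beyond the scatter. How large the step truly is stays hidden because compound 1 sits at a limit: the limit of > 100000 nM in this assay, at which 2 of the 4 values shown sit.

Going by these compounds, whether an amine or a carboxylic acid on this ring would bring the number well below those seen so far remains open. Also open, on these data alone, is whether nitro on a different carbon of the ring would give the same result.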